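The compounds below may be only part of what the source reports. "The series", "measured", "known", "first", "only" and "open" are said of these compounds alone.

In an ADME assay on S9 fraction from liver (Rattus norvegicus) for metabolic stability, with a stated time of 1 h (a lower number here means that less of the compound is left, a higher number that more of the compound is left), compound 1 `CO[C@H]1CC[C@@H](CNc2cc(NCc3cnccc3C(F)(F)F)ncc2C#N)CC1` gives 2% and compound 2 `N#Cc1cnc(NCc2ccccc2C(F)(F)F)cc1N[C@H]1C[C@@H](C(N)=O)C1` gives 83% on the same measure. Compound 3 `N#Cc1cnc(NCc2cncnc2C(F)(F)F)cc1N[C@H]1CC[C@@H](O)CC1` at 76% lies within the scatter of compound 2 and well beyond the scatter above compound 1. Compound 4 `N#Cc1cnc(NCc2cncnc2-c2ccccc2)cc1N[C@H]1CC[C@@H](O)CC1` has phenyl in place of trifluoromethyl on an aromatic carbon and has no number yet. Among the measured compounds shown here, no two measured compounds differ in one place only, so there is no direct precedent and this is a loose expectation: a moderate fall beyond the scatter, estimated as a number 26 percentage points lower from compound 3 to compound 4 (beyond the scatter) in size. For compound 4 the estimated value is 50% with 20% to 80% as the expected range.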

Compound 4, percent of the compound remaining: 78%
The estimate for compound 4 lay 28 percentage points below the measured number; the range from low to high includes it.
By their numbers in this assay, from the lowest: compound 1; then compounds 3, 4 and 2 (each within the scatter of the next).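

Replacing trifluoromethyl with phenyl on an aromatic carbon, next to the ring nitrogen, gives a number 2 percentage points higher from compound 3 to compound 4 (within the scatter) in this assay. At this place on the shared core, then, a trifluoromethyl group and a six-carbon aromatic ring leave the two compounds indistinguishable in this measure. No measurement shown here explains this result. As far as these compounds go, how an amine or a methyl group at this place would read remains open. From the compounds shown here alone, it is also open whether phenyl and trifluoromethyl would match when the rest of the molecule differs.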